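The source may hold more compounds than are shown below. What is called first, only, known or untested is meant among the compounds shown, and "the series" means these compounds.

Among the compounds with values here, in a physicochemical assay for solubility (on this read-out higher numbers stand for higher solubility and lower numbers for lower solubility), compound 1 (`COc1ccc(-n2cnc3cnc(-c4ccc(F)cc4C)cc32)cc1`) gives 117000 nM and compound 2 (`CCOc1ccc(-n2cnc3cnc(-c4ccc(F)cc4C)cc32)cc1`) gives 12000 nM as the lowest of the two numbers so far. Compound 3 (`Cc1cc(F)ccc1-c1cc2c(cn1)ncn2-c1ccc(S(C)(=O)=O)cc1`) differs from compound 2 by methylsulfonyl in place of ethoxy on an aromatic carbon. Within the data shown here, no measured compound carries methylsulfonyl, so only one step bears on this change. On the strength of a 9.8-fold lower number from compound 1 to compound 2 (0.99 log units; beyond the scatter) (modest, beyond the scatter) a step of up to that size towards a higher number is expected in this assay for this change. The expected step is a 2.5-fold higher number from compound 2 to compound 3 (0.40 log units; beyond the scatter) in this estimate. For compound 3 the estimated value is 30000 nM with an expected range of 8000 nM to 120000 nM in repeat measurements.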

Compound 3, solubility: > 200000 nM
Compound 3 gave a limit, no number (the forecaster's own chance of this, stated with the estimate: 5%); middle value at least 6.6-fold (0.82 log units) away from the limit.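

At this position, on an aromatic carbon para to a large group, the read-out in this assay can also move upward: compound 3 gives > 200000 nM, which is a limit of the assay and not a number. Methylsulfonyl in place of ethoxy gives an at least 16-fold higher number from compound 2 to compound 3 (1.22 log units; beyond the scatter), a large step. Methylsulfonyl in place of methoxy gives an at least 1.7-fold higher number from compound 1 to compound 3 (0.23 log units; that floor lies within the scatter), so the order of this pair remains unsettled.

Going by these compounds, the true value of compound 3 remains open. Also open, on these data alone, is how an amine, a carboxylic acid or a chain longer than ethoxy would read at this position.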